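Moving the hydantoin Ring Out by One Methyl

A few compounds are considered here, and "the series" means these few. Any claim that something is new, unique, unknown or untested is made for them only; others in the source may bear on it.

Measured so far:
- compound 1 `CC(C)[C@@H](C[C@H]1SC(=O)NC1=O)c1ccc(-c2ccc3cccc(F)c3c2)[nH]c1=O`: 0.77 h
- compound 2 `CC(C)C(c1ccc(-c2ccc3cccc(F)c3c2)[nH]c1=O)C1C(=O)NC(=O)N1C`: 0.263 h
- compound 3 `CC(C)[C@@H](c1ccc(-c2ccc3cccc(F)c3c2)[nH]c1=O)[C@@H]1OC(=O)NC1=O`: 1.27 h

These three compounds share a core and differ in the ring hung on the side chain. In an ADME assay on microsomes from liver (Rattus norvegicus) for metabolic stability (on this read-out lower numbers stand for a shorter-lived compound and higher numbers for a longer-lived compound), compound 2 gives 0.263 h, the shortest of the three; compound 1 gives 0.77 h, a longer-lived compound, and compound 3 gives 1.27 h, longer still, both gaps beyond the scatter.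

Compound 4 `CC(C)C(CC1C(=O)NC(=O)N1C)c1ccc(-c2ccc3cccc(F)c3c2)[nH]c1=O` has not yet been measured. It keeps the ring of compound 2 but carries it on a methyl: (3-methyl-2,5-dioxoimidazolidin-4-yl)methyl in place of 3-methyl-2,5-dioxoimidazolidin-4-yl on a saturated chain carbon bound to an aromatic carbon and a saturated chain carbon. Compound 1 also carries its ring on a methyl, compound 3 does not, and their values show no clear direction for such a link, as both ring types also differ.

For compound 4 the step of a 1.5-fold higher number from compound 2 to compound 4 (0.18 log units; within the scatter) is expected to be small and upward, barely beyond the scatter. Compound 4 is estimated to give 0.4 h in this assay, within 0.15 h to 1 h.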

Compound 4, half-life: < 0.0667 h
Compound 4 gave a limit, no number (the forecaster's own chance of this, stated with the estimate: 5%); middle value at least 5.9-fold (0.77 log units) from the limit.
By their numbers in this assay, from the lowest: compound 2; then compounds 1 and 3 (each within the scatter of the next). At a limit, below all of these: compound 4.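

Placing the ring of compound 2 on a methyl, with the ring itself unchanged, is the first change here made in one place only, and in this assay it gives an at least 3.9-fold lower number from compound 2 to compound 4 (0.59 log units; beyond the scatter). Compound 4 stands at a limit of the assay, not at a number: the limit of < 0.0667 h in this assay, at which 1 of the 4 values shown sits. This shows that the compound's lifetime is sensitive to how the ring is attached at this saturated chain carbon, a direction that compounds 1 and 3 could not reveal, and the real gap may be larger than the step printed.

The compounds shown do not tell which part of compound 4 is lost faster, and no line here gives a cause. Still open, on these data alone, is whether an ethyl link, or an amine or ether oxygen as the link, would behave like this methyl.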